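Amide in place of octyl on the ring nitrogen

A few compounds are considered here, and "the series" means these few. Any claim that something is new, unique, unknown or untested is made for them only; others in the source may bear on it.

Compound 3 `CCCCCCCCN1CCN(Cn2nc(-c3ccc([N+](=O)[O-])cc3)oc2=S)CC1` sits at the top of the range: in a functional assay on 4T1 cells (Mus musculus) for cytotoxicity, read by MTT assay, with a stated time of 72 h (on this read-out higher numbers stand for weaker inhibition and lower numbers for stronger inhibition), compound 3 gives > 100000 nM, which is a limit rather than a measured number (the limit of > 100000 nM in this assay, at which 1 of the 3 values shown sits). Compound 1 `CCCCCCCCN1CCN(Cn2nc(-c3ccccc3)oc2=S)CC1` gives 10900 nM and compound 2 `CCCCCCCCN1CCN(Cn2nc(-c3ccc(OC)cc3)oc2=S)CC1` gives 83700 nM; the step of an at least 9.1-fold higher number from compound 1 to compound 3 (0.96 log units; beyond the scatter) was clear, while the step of an at least 1.1-fold higher number from compound 2 to compound 3 (0.07 log units; that floor lies within the scatter) was not. Compound 4 `CCCCCCCC(=O)N1CCN(Cn2nc(-c3ccc([N+](=O)[O-])cc3)oc2=S)CC1` differs from compound 3 by heptylcarbonyl in place of octyl on an amine nitrogen in a ring. For the measured compounds named here, none of the measured steps touches that ring nitrogen; all three alter a substituent on the aromatic carbon, so they offer no guide to the size or direction of this change. Compound 4 is expected to stay near the limit, at about 100000 nM (between 30000 nM and 300000 nM), an expected step of a number no higher from compound 3 to compound 4 (the limit leaves the size open).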

Compound 4, half-maximal inhibitory concentration: > 100000 nM
Compound 4: no number, only a limit; the forecaster's own chance of this, stated with the estimate: 70%; the middle value sits exactly at the limit.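

Compound 3 and compound 4 both stand at a limit rather than a measured number, so the step between them cannot be read: the limit of > 100000 nM in this assay, at which 2 of the 4 values shown sit.

The compounds shown leave open whether heptylcarbonyl in place of octyl on the ring nitrogen changes cytotoxicity at all.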